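The source may hold more compounds than are shown below. What is called first, only, known or untested is meant among the compounds shown, and "the series" means these compounds.

Compound 1 `O=C(O)c1ccccc1-c1ccc(CCc2ncc(CC3CCOCC3)[nH]2)cc1`: 338 nM
Compound 2 `O=C(O)c1ccccc1-c1ccc(CCc2ncc(CCc3ccccc3)[nH]2)cc1`: 1320 nM

Going by the values given here, in an in vitro functional assay on cells for agonist activity at Bombesin receptor subtype-3 (Homo sapiens), read by luminescence and calcium flux (a lower number here means that less compound is needed, a higher number that more compound is needed for the effect), compound 2 stands at the higher of the two numbers, and its only neighbour is compound 1, reached by a 3.9-fold higher number from compound 1 to compound 2 (0.59 log units; beyond the scatter). Compound 3 `CC(C)(C)Cc1cnc(CCc2ccc(-c3ccccc3C(=O)O)cc2)[nH]1` is the next step in this series: the change is tert-butyl in place of benzyl on a saturated chain carbon bound to an aromatic carbon. Among the compounds with values here, no measured step covers this exact replacement. Within the data shown here, the one step available, from oxan-4-yl to benzyl, moved the number modestly upward, so a saturated group on this carbon has so far gone with the lower number; tert-butyl is saturated too, but carries no ring and is smaller than oxan-4-yl, so the comparison is loose. The expected step is therefore a 2.6-fold lower number from compound 2 to compound 3 (0.42 log units; beyond the scatter), a lower number but with wide uncertainty. For compound 3 the estimate in this assay is 500 nM, expected to lie between 150 nM and 2000 nM.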

Compound 3, half-maximal effective concentration: 106 nM
Beside the measured number, compound 3's estimate is 4.7-fold (0.67 log units) above it; the measured number lies below the stated range.
By their numbers in this assay, from the lowest: compound 3; then compound 1; then compound 2.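

In this assay, replacing benzyl with tert-butyl on this saturated chain carbon gives a 12-fold lower number from compound 2 to compound 3 (1.10 log units; beyond the scatter), a large step that shows how much the number at this position can move. Replacing oxan-4-yl with tert-butyl gives a 3.2-fold lower number from compound 1 to compound 3 (0.50 log units; beyond the scatter), so the two groups without an aromatic ring also differ from each other beyond the scatter, and a ring of either kind is not needed here for the lowest of the three numbers. The compounds come with no evidence that would explain these differences.

The compounds shown leave open how a cyclohexyl ring, a plain isobutyl chain or an amine would read on this carbon. They also leave open whether the order seen with tert-butyl, oxan-4-yl and benzyl would hold for such groups.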